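Adding a second methoxy to the aryl ketone

This account rests on a few compounds, and the source may have more. Where it says the series, first, only, none or still open, it means among the compounds named here.

compound 1, `COc1cc(-c2cc(/C=C/C(=O)c3ccc(Cl)c(Cl)c3)[nH]n2)cc(OC)c1OC`: > 100000 nM
compound 2, `COc1ccc(C(=O)/C=C/c2cc(-c3cc(OC)c(OC)c(OC)c3)n[nH]2)cc1`: 4070 nM

Both compounds share one core and differ only in the aryl group on the carbonyl carbon. In a functional assay on NCI-H322M cells (Homo sapiens) for inhibition, read by sulforhodamine B assay, with a stated time of 48 h (on this read-out lower numbers stand for stronger inhibition of growth and higher numbers for weaker inhibition of growth), compound 1 reaches no number at all; what stands for compound 1 is the limit of > 100000 nM in this assay, at which 1 of the 2 values shown sits. Going by the values given here, compound 2 gives 4070 nM in this assay, the only number in the set, and the step of an at least 24-fold lower number from compound 1 to compound 2 (1.39 log units; beyond the scatter) describes the change 4-methoxyphenyl in place of 3,4-dichlorophenyl on a carbonyl carbon.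

Compound 3, `COc1ccc(C(=O)/C=C/c2cc(-c3cc(OC)c(OC)c(OC)c3)n[nH]2)cc1OC`, is not yet measured. It differs from compound 2 by methoxy in place of hydrogen on an aromatic carbon, and the place is an aromatic carbon of a six-membered aromatic ring of carbon only, ortho to a methoxy group, meta to a large group. Among the compounds with values here, no measured step adds a methoxy group; the one measured step swaps the whole aryl group, so it bears only loosely on this change. A step within the scatter is therefore expected in this assay, in either direction. For compound 3 the estimate is 3500 nM, between 1000 nM and 12000 nM, which is an expected step of a 1.2-fold lower number from compound 2 to compound 3 (0.07 log units; within the scatter).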

Compound 3, concentration for total growth inhibition: 2900 nM
Beside the measured number, compound 3's estimate is 1.2-fold (0.08 log units) above it; low and high end bracket the measured number.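

In this assay, methoxy in place of hydrogen on this aromatic carbon, ortho to a methoxy group and meta to a large group, gives a 1.4-fold lower number from compound 2 to compound 3 (0.15 log units; within the scatter), so this position takes the added group without a change that can be told from the scatter. The 3,4-dimethoxyphenyl group also stands apart from the 3,4-dichlorophenyl group, with an at least 34-fold lower number from compound 1 to compound 3 (1.53 log units; beyond the scatter), so the large gap seen with the 4-methoxyphenyl group holds for a second methoxy-bearing aryl group. That step is only a bound, as compound 1 has a limit and not a number: the limit of > 100000 nM in this assay, at which 1 of the 3 values shown sits.

The compounds shown leave open whether a hydroxy group, an ethoxy group or an amine on this aromatic carbon would move the number. They also leave open what a single chlorine there would do with the 4-methoxy group kept.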